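Replacing Ethynyl by Nitro on the Aryl Triazole

The source may report more compounds than this note shows. Statements on the series, on what has been measured and on what is new or still open speak of the compounds shown alone.

Compound 3 `C#Cc1ccc(-c2cn(CC(=O)Nc3cc(C)on3)nn2)cc1` reaches only the limit in a functional assay on BMDM cells (Mus musculus, strain C57BL/6) for inhibition, with a stated time of 2 days (on this read-out lower numbers stand for stronger inhibition and higher numbers for weaker inhibition), giving > 30000 nM; this is a limit, not a number, and it is the limit of > 30000 nM in this assay, at which 1 of the 3 values shown sits. Compound 1 `Cc1cc(NC(=O)Cn2cc(-c3ccc(Cl)cc3)nn2)no1` gives 1910 nM in this assay. Compound 2 `O=C(Cn1cc(-c2ccc([N+](=O)[O-])cc2)nn1)Nc1nccs1`, which carries a nitro group on the same kind of aromatic ring but a different amide partner, gives 1040 nM. Compound 4 `Cc1cc(NC(=O)Cn2cc(-c3ccc([N+](=O)[O-])cc3)nn2)no1` is the nitro counterpart of compound 3: nitro in place of ethynyl on an aromatic carbon. Among the measured compounds shown here, the one measured step bearing on this is an at least 15-fold higher number from compound 1 to compound 3 (1.19 log units; beyond the scatter), which marks ethynyl as the weak point; removing it should reverse that loss, and compound 2 shows that nitro is compatible with activity of this order. Compound 4 is therefore expected to show a large drop in the number, an at least 20-fold lower number from compound 3 to compound 4 (1.30 log units; beyond the scatter), with an estimate of 1500 nM (range 500 nM to 6000 nM).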

Compound 4, half-maximal inhibitory concentration: 1220 nM
The estimate for compound 4 lay 1.2-fold (0.09 log units) above the measured number, and the stated range covers the measured number.
By their numbers in this assay, from the lowest: compounds 2, 4 and 1 (each within the scatter of the next). At a limit, above all of these: compound 3.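

In this assay, nitro in place of ethynyl on this aromatic carbon, para to a large group, gives an at least 24-fold lower number from compound 3 to compound 4 (1.39 log units; beyond the scatter), so a group at this place can restore the activity lost with ethynyl. Nitro and chloro are not told apart, with a 1.6-fold lower number from compound 1 to compound 4 (0.19 log units; within the scatter), and 5-methyl-1,2-oxazol-3-yl in place of 1,3-thiazol-2-yl on the amide nitrogen gives a 1.2-fold higher number from compound 2 to compound 4 (0.07 log units; within the scatter), also within the scatter. The first step is only a bound, since compound 3 is a limit, not a number: the limit of > 30000 nM in this assay, at which 1 of the 4 values shown sits.

The compounds shown leave open how an amine or a carboxylic acid would fare at this carbon. They also leave open why ethynyl alone stands apart from chloro and nitro.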